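The compounds below may be only part of what the source reports. "The series", "measured", "known", "first", "only" and "open" are said of these compounds alone.

Working notes on the series

Compound 2 `CCN(CC)C(=O)[C@@H]1CN[C@H](C(=O)N2CCC[C@H]2C#N)C1` stands lowest of the three measured compounds in an assay on the whole organism (plasma, strain Sprague-Dawley) for inhibition of Dipeptidyl peptidase 4 (Rattus norvegicus), with a stated time of 6 h, at a dose of 1 mg/kg by the oral route (a higher number here means more inhibition at the dose given (going by the name of the read-out), a lower number less inhibition), giving 43%. Compound 1 `N#C[C@@H]1CCCN1C(=O)[C@@H]1C[C@H](C(=O)N2CCCCCCC2)CN1` gives 63% and compound 3 `CCN(C)C(=O)[C@H]1C[C@@H](C(=O)N2CCC[C@H]2C#N)N[C@H]1C` gives 92%, both beyond the scatter from compound 2. Compound 4 `N#C[C@@H]1CCCN1C(=O)[C@@H]1CCCN1` differs from compound 2 by hydrogen in place of diethylcarbamoyl on a saturated ring carbon. Among the measured compounds shown here, the only measured step at this position, a number 20 percentage points lower from compound 1 to compound 2 (beyond the scatter), exchanges one carbamoyl group for another and does not cover removal of the group altogether, so it bears on the change only loosely. Removing the diethylcarbamoyl is expected to lower inhibition, with a step of a number 15 percentage points lower from compound 2 to compound 4 (beyond the scatter) expected. For compound 4 the estimate in this assay is 28%, between 5% and 55%.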

Compound 4, a percentage reported as inhibition, in the whole organism at one dose (the size of the read-out at that dose, not a potency): 20%
Estimate against measurement, compound 4: 8 percentage points above; the measured number falls inside the stated range.
By their numbers in this assay, from the lowest: compound 4; then compound 2; then compound 1; then compound 3.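

In this assay, replacing diethylcarbamoyl with hydrogen on the saturated ring carbon gives a number 23 percentage points lower from compound 2 to compound 4 (beyond the scatter). The earlier step exchanged one carbamoyl group for another; this one shows that compound 2, which carries the group, gives more inhibition at this dose than compound 4, which has none at this position. The group therefore adds to the read-out here, at least for this pair.

On these data alone, whether a carboxylic acid, an amine or a simple methyl on this carbon would also raise the number over compound 4 remains open. Nothing measured here gives a reason for the step.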